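The compounds below may be only part of what the source reports. "The series", "measured", "known", "first", "only" and "open" are said of these compounds alone.

Working notes on the series. Compound 1 `CC(C)=CCC[C@](C)(O)c1ccc(C)cc1` and compound 2 `Cc1ccc([C@]2(C)CC[C@@H](C(C)(C)O)O2)cc1` open the set, and both have been run in the same assay. In an ADME assay on K562 cells (Homo sapiens) for inhibition, read by MTT assay, with a stated time of 5 days (a lower number here means a stronger inhibitor, a higher number a weaker inhibitor), compound 1 gives > 50000 nM, which is a limit of the assay and not a number. In this assay compound 2 likewise gives only > 50000 nM, again a limit rather than a measured value. Among the measured compounds shown here, compound 2 therefore stands at the limit, and the one other value seen so far in this assay sits there as well (the limit of > 50000 nM in this assay, at which 2 of the 2 values shown sit). For the measured compounds named here, no step between measured compounds can be computed, since neither value is a number.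

Compound 3 `Cc1ccc([C@]2(C)CC[C@@H](C(C)(C)O)O2)cc1O` is the next member and differs from compound 2 by hydroxy in place of hydrogen on an aromatic carbon. Going by the values given here, the two values seen so far give no direction for this change and no size for any step in this assay. The expectation is that the step of a number no higher from compound 2 to compound 3 (the limit leaves the size open) lies within the scatter, with a good chance that the assay again reports only a limit. Compound 3 is expected at 50000 nM, with a range from 15000 nM to 150000 nM.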

Compound 3, half-maximal inhibitory concentration: > 50000 nM
Compound 3 gave a limit, no number; the forecaster's own chance of this, stated with the estimate: 70%; the middle value lies on the limit itself.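

In this assay, among the compounds shown here, compound 3 gives > 50000 nM, a limit and not a number, so no step between compound 2 and compound 3 can be read. The compounds shown leave open whether hydroxy in place of hydrogen on an aromatic carbon alters inhibition, and where any of the three compounds would give an actual number.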